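Replacing the Amine on the Thiocarbonyl Carbon: Compound 3

A few compounds are considered here, and "the series" means these few. Any claim that something is new, unique, unknown or untested is made for them only; others in the source may bear on it.

Measured so far:
compound 1, `Nc1ccccc1NC(=O)c1ccc(CSC(=S)N2CCCc3ccccc32)cc1`: 87.5%
compound 2, `Nc1ccccc1NC(=O)c1ccc(CSC(=S)N2CCc3cc(Cl)ccc32)cc1`: 82.2%

In a functional assay on MGC-803 cells (Homo sapiens) for antiproliferative activity, read by CCK-8 assay, with a stated time of 72 h, tested at 8 uM (a higher number here means a stronger effect of the compound at the concentration tested, a lower number a weaker effect), compound 1 gives 87.5% and compound 2 gives 82.2%. Going by the values given here, compound 2 holds the lower of the two numbers, with compound 1 as its only neighbour, but the step of a number 5.3 percentage points lower from compound 1 to compound 2 (within the scatter) lies within the scatter, so the two cannot be ordered.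

Compound 3 `CCN(Cc1ccncc1)C(=S)SCc1ccc(C(=O)Nc2ccccc2N)cc1` has not yet been measured. It differs from compound 2 in one place: ethyl((pyridin-4-yl)methyl)amino in place of 5-chloro-2,3-dihydro-1H-indol-1-yl on a thiocarbonyl carbon. Among the compounds with values here, the only measured step at the same place, on a thiocarbonyl carbon, is a number 5.3 percentage points lower from compound 1 to compound 2 (within the scatter), and it was small. Within the data shown here, that step exchanged 1,2,3,4-tetrahydroquinolin-1-yl for 5-chloro-2,3-dihydro-1H-indol-1-yl, whereas the group entering now is ethyl((pyridin-4-yl)methyl)amino, with one six-membered aromatic ring with 1 hetero atom and 1 hydrogen-bond acceptor, so the single precedent is a thin guide. Nothing measured points to a change beyond the scatter, and the step of a number 4.2 percentage points lower from compound 2 to compound 3 (within the scatter) is therefore expected to be small, with a wide range to reflect the sparse evidence. For compound 3 the estimated value in this assay is 78%, expected to fall between 55% and 92%.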

Compound 3, a percentage reported as inhibition, at one concentration (the size of the read-out at that concentration, not a potency): 85.2%
Estimate against measurement, compound 3: 7.2 percentage points below, and the stated range covers the measured number.
By their numbers in this assay, from the lowest: compounds 2, 3 and 1 (each within the scatter of the next).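

With this assay as the measure, ethyl((pyridin-4-yl)methyl)amino can replace 5-chloro-2,3-dihydro-1H-indol-1-yl on the thiocarbonyl carbon, giving a number 3 percentage points higher from compound 2 to compound 3 (within the scatter). Replacing 1,2,3,4-tetrahydroquinolin-1-yl with the same group gives a number 2.3 percentage points lower from compound 1 to compound 3 (within the scatter), so the three groups cannot be told apart here, even though the new one brings a six-membered aromatic ring with 1 hetero atom and a hydrogen-bond acceptor, where 5-chloro-2,3-dihydro-1H-indol-1-yl has none. This position therefore tolerates more variety than the first pair could show, but no measurement at hand gives a reason for that tolerance.

On these data alone, it remains open whether a much smaller amine such as dimethylamino, or an amine carrying a carboxylic acid, would hold the read-out in the same range or move it beyond the scatter. The read-out is also the size of the effect at a single concentration, so it cannot show whether compounds 1, 2 and 3 would give a stronger or weaker effect than one another at any other concentration.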